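Fluoro to bromo: one small change, one expectation

The source may report more compounds than this note shows. Statements on the series, on what has been measured and on what is new or still open speak of the compounds shown alone.

Measured so far in a functional assay on NCI-H1581 cells (Homo sapiens) for inhibition, read by MTT assay, with a stated time of 48 h, tested at 10 uM; on this read-out higher numbers stand for more inhibition at the one concentration tested (going by the name of the read-out) and lower numbers for less inhibition:
compound 1 `COc1cc(NC(=O)Nc2cc(Nc3ccc(F)c(Cl)c3)ncn2)cc(OC)c1` gives 53%
compound 2 `COc1cc(NC(=O)Nc2cc(Nc3cc(F)ccc3OC)ncn2)cc(OC)c1` gives 42.1%

Compound 2 stands at the lower of the two numbers. Among the measured compounds shown here, its only neighbour is compound 1, and the step of a number 10.9 percentage points lower from compound 1 to compound 2 (beyond the scatter) lies beyond the usual scatter of repeated measurements of this kind. That step exchanged one whole aromatic group for another on the nitrogen, so it speaks about a larger rebuild than the one considered here.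

Compound 3 `COc1cc(NC(=O)Nc2cc(Nc3cc(Br)ccc3OC)ncn2)cc(OC)c1` has not yet been tested. It differs from compound 2 in one place: bromo in place of fluoro on an aromatic carbon. For the measured compounds named here, no measured step describes an exchange of one halogen for another on an aromatic carbon; the one known step of a number 10.9 percentage points lower from compound 1 to compound 2 (beyond the scatter) touched a different part of the molecule and offers no direct guide. With nothing to point either way, the cautious expectation is a step no larger than the scatter, and the estimated step is a number 2.9 percentage points higher from compound 2 to compound 3 (within the scatter). Compound 3 is therefore expected to give about 45% in this assay, with a range from 30% to 60%.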

Compound 3, a percentage reported as inhibition, at one concentration (the size of the read-out at that concentration, not a potency): 23.1%
Compound 3: middle estimate off by 21.9 percentage points, on the high side; measured number outside the range, below it.
By their numbers in this assay, from the lowest: compound 3; then compound 2; then compound 1.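

In this assay, a halogen exchange on an aromatic carbon, meta to a large group and para to a methoxy group, proves far from silent: bromo in place of fluoro brings a number 19 percentage points lower from compound 2 to compound 3 (beyond the scatter), although one heavy atom simply replaces another and the count of hydrogen-bond donors and acceptors stays the same. Set against the other aromatic group on the nitrogen, the 5-bromo-2-methoxyphenyl group gives a number 29.9 percentage points lower from compound 1 to compound 3 (beyond the scatter), so compound 3 now stands lowest of the three, with its steps to both others beyond the scatter. Nothing at hand explains why this exchange lowers the number at this position.

Open, from the compounds shown here alone, is how other groups on this same aromatic carbon would read, whether a plain hydrogen, iodo, a nitrile or an amine, and so whether bromo is a special case or part of a wider trend. Also open, going by these compounds, is whether the same exchange of fluoro for bromo would bring a similar step in another aromatic group on the nitrogen, such as the 3-chloro-4-fluorophenyl group of compound 1.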